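Bromo for methoxy: one measured step, one expected

This account rests on a few compounds, and the source may have more. Where it says the series, first, only, none or still open, it means among the compounds named here.

Measured in a functional assay on A549 cells (Homo sapiens) for inhibition, read by CCK-8 assay, with a stated time of 72 h, tested at 1 uM; on this read-out higher numbers stand for more inhibition of growth at the one concentration tested and lower numbers for less inhibition of growth:
compound 1, `COc1ccc(NC(=O)C2(C(=O)Nc3ccc(Nc4ncc5cc(C(=O)N(C)C)n(C6CCCC6)c5n4)cc3)CC2)cc1`: 74.4%
compound 2, `CN(C)C(=O)c1cc2cnc(Nc3ccc(NC(=O)C4(C(=O)Nc5ccc(Br)cc5)CC4)cc3)nc2n1C1CCCC1`: -6.6%
compound 3, `COc1cccc(NC(=O)C2(C(=O)Nc3ccc(Nc4ncc5cc(C(=O)N(C)C)n(C6CCCC6)c5n4)cc3)CC2)c1`: 77.2%

Compound 1 and compound 3 share one core and differ only in 3-methoxyphenyl in place of 4-methoxyphenyl on an amide-type nitrogen; the step of a number 2.8 percentage points higher from compound 1 to compound 3 (within the scatter) is within the scatter, so the two are read as alike. Compound 2 stands far off: a number 81 percentage points lower from compound 1 to compound 2 (beyond the scatter), and likewise a number 83.8 percentage points higher from compound 2 to compound 3 (beyond the scatter). For the measured compounds named here, the single change behind the drop from compound 1 to compound 2 is bromo in place of methoxy on an aromatic carbon.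

Compound 4, `CN(C)C(=O)c1cc2cnc(Nc3ccc(NC(=O)C4(C(=O)Nc5cccc(Br)c5)CC4)cc3)nc2n1C1CCCC1`, is not yet measured. It differs from compound 3 by bromo in place of methoxy on an aromatic carbon. This is the same kind of change as from compound 1 to compound 2, but not the same: there the group sat para to a large group, here it sits meta to a large group. The two cores differ by 3-methoxyphenyl in place of 4-methoxyphenyl on an amide-type nitrogen, as already told.

Going by the values given here, only one measured step speaks for the change, and it is large. For compound 4 the expected step is a number 67.2 percentage points lower from compound 3 to compound 4 (beyond the scatter), resting on the size of a number 81 percentage points lower from compound 1 to compound 2 (beyond the scatter) in compound 2. That one example was para to a large group and this one is meta to a large group. The range is kept wide. The estimate for compound 4 in this assay is 10%, expected to lie between -15% and 55%.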

Compound 4, percent growth inhibition at one concentration: 20.2%
Compound 4: middle estimate off by 10.2 percentage points, on the low side; the measured number falls inside the stated range.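

In this assay, bromo in place of methoxy on an aromatic carbon again goes with a number 57 percentage points lower from compound 3 to compound 4 (beyond the scatter) and so keeps its direction from the core of compound 1 to the core of compound 3, but the size of the step does not carry over unchanged: the same change on two cores in this assay, a number 81 percentage points lower (beyond the scatter) from compound 1 to compound 2 and a number 57 percentage points lower (beyond the scatter) from compound 3 to compound 4, 24 percentage points apart, beyond the scatter of two such steps.

The placing of the group also reads differently for the two substituents, since 3-bromophenyl in place of 4-bromophenyl gives a number 26.8 percentage points higher from compound 2 to compound 4 (beyond the scatter) while the matching methoxy pair shows a number 2.8 percentage points higher from compound 1 to compound 3 (within the scatter) and reads as alike. The step with a number 54.2 percentage points lower from compound 1 to compound 4 (beyond the scatter) changes both the substituent and its place at once, so it separates neither, and two cores show only that the direction held here, not that it would hold on a further core, nor why the size differs.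

Among the compounds shown, the phenyl ring carries only methoxy or bromo, so it remains open how the series would read with chloro, a dimethylamino group or a carboxylic acid in those places. As far as these compounds go, with one concentration behind each number, it also remains open how these steps would look across a range of concentrations.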